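This account rests on a few compounds, and the source may have more. Where it says the series, first, only, none or still open, it means among the compounds named here.

Series notes. Compound 1 `O=C(O)CC(CC(=O)NNC(=O)CCCCNc1ccccn1)c1ccc(Br)cc1`, compound 2 `COc1ccc(C(CC(=O)O)CC(=O)NNC(=O)CCCCNc2ccccn2)cc1` and compound 3 `O=C(O)CC(NC(=O)NNC(=O)CCCCNc1ccccn1)c1ccc(Br)cc1` have been measured in a physicochemical assay for lipophilicity; on this read-out lower numbers stand for lower lipophilicity and higher numbers for higher lipophilicity; compound 4 `COc1ccc(C(CC(=O)O)NC(=O)NNC(=O)CCCCNc2ccccn2)cc1` has not. In this assay compound 1 gives 2.9, compound 2 gives 1.94 and compound 3 gives 2.47. Compound 1 and compound 2 differ in one place only: methoxy in place of bromo on an aromatic carbon. That change produced a number 0.96 log units lower from compound 1 to compound 2 (beyond the scatter). The difference between the two cores, that of compound 1 and that of compound 3, is not broken down here; compound 3 sits second highest of the three measured values.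

Compound 4 carries the same change on the core of compound 3: methoxy in place of bromo on an aromatic carbon. The place is the same in both pairs, so this is the same change, made for the second time in the set. The earlier step of a number 0.96 log units lower from compound 1 to compound 2 (beyond the scatter) lies beyond the scatter. Between compound 3 and compound 4 nothing else moves, so a step of similar size is expected in this assay, namely a number 0.96 log units lower from compound 3 to compound 4 (beyond the scatter). On that basis compound 4 is estimated at 1.51, plausibly between 1.15 and 1.85.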

Compound 4, partition coefficient: 1.52
Beside the measured number, compound 4's estimate is 0.01 log units below it, and the stated range covers the measured number.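

In this assay, methoxy in place of bromo on an aromatic carbon gives a number 0.95 log units lower from compound 3 to compound 4 (beyond the scatter), and on the other core the same change gave a number 0.96 log units lower from compound 1 to compound 2 (beyond the scatter). Within this series the change therefore carries from the core of compound 1 to the core of compound 3 with a step of nearly the same size, and no compound shown goes against this, although two pairs on two cores cannot establish a rule for cores beyond these. The numbers describe only the size and direction of the step, and nothing shown explains why it repeats.

Still open, on these data alone, is whether a third core, differing from these two elsewhere in the structure, would give a step of similar size. Also open, as far as these compounds go, is how this place responds to other groups, such as chloro, nitrile, an amine or a longer ether chain in place of methoxy, and whether their steps would also carry from one core to the other.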